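Replacing the sulfur-linked group of compound 2

A few compounds are considered here, and "the series" means these few. Any claim that something is new, unique, unknown or untested is made for them only; others in the source may bear on it.

Measured in a functional assay on NCI-H1975 cells (Homo sapiens) for inhibition, read by MTT assay, with a stated time of 72 h; on this read-out higher numbers stand for weaker inhibition and lower numbers for stronger inhibition:
compound 1 `Cc1csc(Sc2cc(C(F)(F)F)nc(SCc3ccc(C(F)(F)F)cc3)n2)n1`: 5840 nM
compound 2 `FC(F)(F)c1ccc(CSc2nc(Sc3nnnn3-c3ccccc3)cc(C(F)(F)F)n2)cc1`: 24300 nM

Compound 2, at 24300 nM, has the higher of the two numbers in this assay. Compound 3 `FC(F)(F)c1ccc(CSc2nc(Sc3nncs3)cc(C(F)(F)F)n2)cc1` keeps the shared core and changes one group: 1,3,4-thiadiazol-2-yl in place of 1-phenyl-1H-tetrazol-5-yl on a sulfur. Among the compounds with values here, the only measured step at this place is a 4.2-fold higher number from compound 1 to compound 2 (0.62 log units; beyond the scatter), a modest one, which put 1-phenyl-1H-tetrazol-5-yl in place of 4-methyl-1,3-thiazol-2-yl. Compound 3 also lacks 1-phenyl-1H-tetrazol-5-yl, and carries a five-membered aromatic ring there, so a return towards compound 1 at 5840 nM is expected, though a single step gives weak support. The expected change is of similar modest size, towards a lower number: a 3.0-fold lower number from compound 2 to compound 3 (0.48 log units; beyond the scatter). For compound 3 the estimated value is 8000 nM, with an expected range of 2500 nM to 22000 nM.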

Compound 3, half-maximal inhibitory concentration: 2270 nM
Estimate against measurement, compound 3: 3.5-fold (0.55 log units) above; measured number below the stated range.
By their numbers in this assay, from the lowest: compound 3; then compound 1; then compound 2.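

In this assay the change gives an 11-fold lower number from compound 2 to compound 3 (1.03 log units; beyond the scatter) and so goes well past a simple return to the earlier level, since it also gives a 2.6-fold lower number from compound 1 to compound 3 (0.41 log units; beyond the scatter) at the same place. The result shows that losing 1-phenyl-1H-tetrazol-5-yl is not the whole story: 1,3,4-thiadiazol-2-yl and 4-methyl-1,3-thiazol-2-yl, both five-membered aromatic rings on this sulfur, are themselves separated beyond the scatter. Nothing available explains this order of the three groups.

The compounds shown do not separate the methyl of 4-methyl-1,3-thiazol-2-yl from the change in ring atoms, as both differ in the step to compound 3. As far as these compounds go, how a plain phenyl ring, an aminoethyl chain or a carboxylic acid on this sulfur would compare also remains open.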